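The source may hold more compounds than are shown below. What is called first, only, known or untested is meant among the compounds shown, and "the series" means these compounds.

Measured so far in this study:
compound 1 `CCOC(=O)c1cccc(-c2nc3ccccc3[nH]2)n1` — 31%
compound 2 `NC(=O)c1cccc(-c2nc3ccccc3[nH]2)n1` — 13%

In a functional assay on the whole organism with Rattus norvegicus as the target, read by paw edema, with a stated time of 3 h, at a dose of 100 mg/kg by the oral route (a higher number here means more inhibition at the dose given (going by the name of the read-out), a lower number less inhibition), compound 1 gives 31%, while compound 2 gives 13%. Compound 2 therefore stands lowest of the two measured numbers; its nearest neighbour is compound 1, separated by a number 18 percentage points lower from compound 1 to compound 2 (beyond the scatter). The next compound, compound 3 `Oc1cccc(-c2nc3ccccc3[nH]2)n1`, differs from compound 2 in a single place: hydroxy in place of carbamoyl on an aromatic carbon. Among the compounds with values here, only one measured step exists, and it describes a change on the carbonyl carbon rather than the removal of the carbamoyl group itself, so it bears on the present step only loosely. Within the data shown here, the data hold no step of the present kind, so no direction can be read from them. For compound 3 in this assay the expected result is 15%, with a range from 0% to 35%. The step this estimate means, a number 2 percentage points higher from compound 2 to compound 3 (within the scatter), is expected to remain within the scatter.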

Compound 3, a percentage reported as inhibition, in the whole organism at one dose (the size of the read-out at that dose, not a potency): -7%
For compound 3 the middle estimate is 22 percentage points above the measured one; the whole stated range lies above it.
By their numbers in this assay, from the lowest: compound 3; then compound 2; then compound 1.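

In this assay, hydroxy on this aromatic carbon gives a number 20 percentage points lower from compound 2 to compound 3 (beyond the scatter) when it replaces carbamoyl, and a number 38 percentage points lower from compound 1 to compound 3 (beyond the scatter) when it replaces ethoxycarbonyl. The position therefore responds to losing the whole carbonyl-bearing group, not only to a change on the carbonyl carbon, and the three groups now rank ethoxycarbonyl, carbamoyl, hydroxy from the highest number to the lowest, with compound 3 at -7%, on the negative side of zero. No measurement at hand gives a reason for this order.

The compounds shown leave open how a carboxylic acid or a simple amine would fall in this order at the same carbon. They also leave open whether a longer chain on the ester would move the number above that of compound 1.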